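A few compounds are considered here, and "the series" means these few. Any claim that something is new, unique, unknown or untested is made for them only; others in the source may bear on it.

Measured in a functional assay on ileum for inhibition of histamine H1 receptor (Cavia porcellus); on this read-out higher numbers stand for weaker inhibition and lower numbers for stronger inhibition:
compound 1, `CCCCN1CCCN(c2nc3ccccc3n2CCOCC)CC1`; compound 1 gives 8.4 nM
compound 2, `CCCOCCn1c(N2CCN(C)CC2)nc2ccccc21`; compound 2 gives 20 nM
compound 3, `CCCCN1CCN(c2nc3ccccc3n2CCOCC)CC1`; compound 3 gives 15 nM

Among these three numbers compound 2 has the highest. Its gap to compound 3 is within the usual scatter of such measurements, so the two cannot be told apart. Its gap to compound 1 is beyond the scatter, so compound 1 inhibits more strongly than compound 2. Among the measured compounds shown here, none of the three measured pairs differ from each other in a single place, so no measured step is available as a guide.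

Compound 4, `CN1CCN(c2nc3ccccc3n2CCO)CC1`, has not yet been measured. Compared with compound 2 the change is hydrogen in place of propyl on an oxygen on a saturated carbon. For the measured compounds named here, nothing among the measured compounds shows this change, so its effect is uncertain. A shift towards a higher number, at about the edge of the scatter, is expected: the step from compound 2 to compound 4 in this assay is estimated as a 2.0-fold higher number from compound 2 to compound 4 (0.30 log units; within the scatter). Compound 4 is therefore expected to give about 40 nM, with a plausible range from 12 nM to 130 nM.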

Compound 4, half-maximal inhibitory concentration: 410 nM
The estimate for compound 4 lay 10-fold (1.01 log units) below the measured number; measured number above the stated range.
By their numbers in this assay, from the lowest: compounds 1, 3 and 2 (each within the scatter of the next, the first and the last beyond it); then compound 4.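

The propyl on this oxygen matters: in this assay, replacing it with hydrogen, which turns 2-propoxyethyl into 2-hydroxyethyl, gives a 21-fold higher number from compound 2 to compound 4 (1.31 log units; beyond the scatter) and so clearly weakens inhibition. Among the compounds shown here, the earlier compounds could not show this, since no two of them differ in one place, and this is the first measured step in the set. Nothing given here explains why the step is so large.

For the compounds shown here, only two groups on this oxygen can be compared directly, propyl and hydrogen, so it stays open whether a methyl or a longer chain such as pentyl would keep the inhibition seen with propyl. Also open, from the compounds shown here alone, is whether an amine in place of the hydroxy would behave more like compound 4 or more like compound 2.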